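Predicting a Trimethoxyphenyl Variant From Three Semicarbazones

The source may hold more compounds than are shown below. What is called first, only, known or untested is meant among the compounds shown, and "the series" means these compounds.

Compound 1, `CN(C)CCn1cnnc1-c1cc(Oc2ccc(NC(=O)N/N=C/c3cccc(Cl)c3Cl)cc2F)ccn1`, gives 1090 nM in a functional assay on A549 cells (Homo sapiens) for cytotoxicity, read by MTT assay, with a stated time of 72 h; a lower number here means a stronger inhibitor, a higher number a weaker inhibitor.
Compound 2, `CN(C)CCn1cnnc1-c1cc(Oc2ccc(NC(=O)N/N=C/c3ccc(O)cc3)cc2F)ccn1`, gives 3560 nM in this assay.
Compound 3, `CN(C)CCn1cnnc1-c1cc(Oc2ccc(NC(=O)N/N=C/c3c[nH]c4ccccc34)cc2F)ccn1`, gives 820 nM in this assay.

Going by the values given here, compound 3 carries the lowest number of the three, though the step of a 1.3-fold lower number from compound 1 to compound 3 (0.12 log units; within the scatter) is within the scatter, so compound 3 and compound 1 cannot be told apart; only the step of a 4.3-fold lower number from compound 2 to compound 3 (0.64 log units; beyond the scatter) is a real difference. All three compounds share one core and differ only in the group on the carbon with a double bond to nitrogen.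

Compound 4, `COc1ccc(/C=N/NC(=O)Nc2ccc(Oc3ccnc(-c4nncn4CCN(C)C)c3)c(F)c2)c(OC)c1OC`, changes that same position: 2,3,4-trimethoxyphenyl in place of 1H-indol-3-yl on a carbon with a double bond to nitrogen. Among the compounds with values here, no measured step contains this exact swap. Within the data shown here, the steps that bear on it are a 3.3-fold higher number from compound 1 to compound 2 (0.51 log units; beyond the scatter), a 1.3-fold lower number from compound 1 to compound 3 (0.12 log units; within the scatter) and a 4.3-fold lower number from compound 2 to compound 3 (0.64 log units; beyond the scatter), all at the same position. The one phenyl ring bearing an oxygen substituent, in compound 2, gave the highest number, while the two-ring group of compound 3 gave the lowest. Compound 4 brings a phenyl ring with three oxygen-bearing groups, so a modest weakening relative to compound 3 is expected, of about a 2.0-fold higher number from compound 3 to compound 4 (0.29 log units; within the scatter).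

Compound 4 is therefore estimated to give 1600 nM in this assay, expected to fall between 600 nM and 4500 nM.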

Compound 4, half-maximal inhibitory concentration: 6680 nM
Beside the measured number, compound 4's estimate is 4.2-fold (0.62 log units) below it; measured number outside the range, above it.
By their numbers in this assay, from the lowest: compounds 3 and 1 (each within the scatter of the next); then compounds 2 and 4 (each within the scatter of the next).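

In this assay, replacing 1H-indol-3-yl with 2,3,4-trimethoxyphenyl on this carbon gives a clear loss, with an 8.1-fold higher number from compound 3 to compound 4 (0.91 log units; beyond the scatter), and the change from the 2,3-dichlorophenyl group is of similar size, with a 6.1-fold higher number from compound 1 to compound 4 (0.79 log units; beyond the scatter). Against the 4-hydroxyphenyl group the step is a 1.9-fold higher number from compound 2 to compound 4 (0.27 log units; within the scatter), so compound 2 and compound 4 cannot be told apart, and the two phenyl rings bearing oxygen groups now form a pair with higher numbers than compound 1 and compound 3. A single phenyl ring does not by itself bring a high number, since compound 1 also carries one and goes against any such rule, staying within the scatter of the two-ring group of compound 3, with a 1.3-fold lower number from compound 1 to compound 3 (0.12 log units; within the scatter).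

Nothing measured here explains why these groups fall into two pairs. The compounds shown also leave open where a phenyl ring carrying an amine or a carboxylic acid at this position would fall, and whether such a ring would sit with compound 3 and compound 1 or with compound 2 and compound 4.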